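Replacing the Arylsulfonamide of Compound 1 with a Methylsulfonamide

A few compounds are considered here, and "the series" means these few. Any claim that something is new, unique, unknown or untested is made for them only; others in the source may bear on it.

Compound 1 `CCc1ccc(S(=O)(=O)N[C@H]2C3CC[C@H](C3)[C@@H]2C/C=C\CCCC(=O)O)cc1` was tested in a functional assay (plasma) for inhibition, with Oryctolagus cuniculus as the target (on this read-out higher numbers stand for weaker inhibition and lower numbers for stronger inhibition), where compound 1 gives 4600 nM. Going by the values given here, this is the lowest of the two numbers measured so far. Among the compounds with values here, the only other measured compound, compound 2 `O=C(O)CCC/C=C\C[C@H]1[C@@H]2CCC(C2)[C@@H]1NS(=O)(=O)c1ccc(C(=O)O)cc1`, gives 800000 nM in this assay; the step of a 170-fold higher number from compound 1 to compound 2 (2.24 log units; beyond the scatter) shows that changing the substituent on the aromatic ring alone moves the number far beyond the scatter.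

Compound 3 `CS(=O)(=O)N[C@H]1C2CC[C@H](C2)[C@@H]1C/C=C\CCCC(=O)O` has not yet been measured. It differs from compound 1 by methyl in place of 4-ethylphenyl on a sulfonyl sulfur. Within the data shown here, no measured step concerns removal of the whole aromatic ring, so the step from compound 1 to compound 2 is only an indirect guide: it shows that this part of the molecule is sensitive to change, but it does not say how a methyl in place of the ring will behave.

Because the step of a 170-fold higher number from compound 1 to compound 2 (2.24 log units; beyond the scatter) was large, a change that removes the ring entirely is expected to weaken inhibition as well, by an estimated 13-fold higher number from compound 1 to compound 3 (1.12 log units; beyond the scatter). Compound 3 is therefore estimated at 60000 nM, with a range from 8000 nM to 500000 nM.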

Compound 3, half-maximal inhibitory concentration: 640000 nM
Estimate against measurement, compound 3: 11-fold (1.03 log units) below; the whole stated range lies below it.
By their numbers in this assay, from the lowest: compound 1; then compounds 3 and 2 (each within the scatter of the next).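

In this assay, replacing the whole 4-ethylphenyl group on the sulfonyl sulfur with methyl gives a 140-fold higher number from compound 1 to compound 3 (2.14 log units; beyond the scatter) and so shows that the low number of compound 1 depends on what this group carries, since a small methyl does not keep it. Placing methyl in the same spot instead of 4-carboxyphenyl gives a 1.3-fold lower number from compound 2 to compound 3 (0.10 log units; within the scatter) and leaves the two compounds level, so an aromatic ring on the sulfonyl sulfur does not by itself give stronger inhibition: with carboxy on it, the ring offers no measurable gain over a plain methyl. Nothing measured here explains why these groups behave as they do.

Going by these compounds, what stays open is which feature of 4-ethylphenyl matters, and a plain phenyl, a propyl chain in place of the ethyl, or an amine on the ring could show whether the ethyl itself counts or whether most ring substituents other than a carboxylic acid would serve as well. A butyl chain on the sulfonyl sulfur could also show whether the ring is needed at all, or whether a larger group of carbon atoms without a ring would do the same.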